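A few compounds are considered here, and "the series" means these few. Any claim that something is new, unique, unknown or untested is made for them only; others in the source may bear on it.

Measured in an ADME assay on microsomes from liver (Rattus norvegicus) for metabolic stability, using NADPH, with a stated time of 10 min; on this read-out lower numbers stand for a less stable compound and higher numbers for a more stable compound:
Compound 1 `NC/C=C/CN(C[C@H]1Cc2ncccc2CN1)[C@H]1CCCc2cccnc21`: 11%
Compound 2 `CN(C)CCCCN(C[C@H]1Cc2ncccc2CN1)[C@H]1CCCc2cccnc21`: 27%

Compound 2 holds the higher of these two numbers. Among the measured compounds shown here, the only measured step is a number 16 percentage points higher from compound 1 to compound 2 (beyond the scatter).

The next compound is compound 3 `c1cnc2c(c1)CN[C@@H](CN(CCCCNC1CCOCC1)[C@H]1CCCc3cccnc31)C2`, which keeps the shared core of compound 2 and alters the end of its chain: (oxan-4-yl)amino in place of dimethylamino on a saturated chain carbon, four bonds along the chain from an amine nitrogen. Here (oxan-4-yl)amino takes the place of dimethylamino on a saturated chain carbon, four bonds along the chain from an amine nitrogen.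

For the measured compounds named here, the one measured step involved a different exchange, so it offers a rough idea of scale but no direction for this change. The expectation therefore stays near compound 2 at 27%, with no clear shift beyond the scatter. The expected change is a number 2 percentage points lower from compound 2 to compound 3 (within the scatter). For compound 3 the estimated value is 25%, with an expected range of 9% to 45%.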

Compound 3, percent of the compound remaining: 49%
Compound 3: middle estimate off by 24 percentage points, on the low side; measured number outside the range, above it.
By their numbers in this assay, from the lowest: compound 1; then compound 2; then compound 3.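

In this assay the far end of the chain proves able to move the number: (oxan-4-yl)amino in place of dimethylamino, four bonds along the chain from an amine nitrogen, gives a number 22 percentage points higher from compound 2 to compound 3 (beyond the scatter) while the shared core stays the same. Replacing 3-aminoprop-1-en-1-yl with 3-((oxan-4-yl)amino)propyl gives a number 38 percentage points higher from compound 1 to compound 3 (beyond the scatter) and so changes the chain along with its end. No available measurement gives a reason for either rise.

The exchange brings in a six-membered ring, an oxygen and a hydrogen on the nitrogen all at once, so the compounds shown do not tell which of these goes with the higher number. Cyclohexylamino, which has a ring but no oxygen, and methylamino, which has neither, would help to separate them at this place.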